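The compounds below may be only part of what the source reports. "The series", "measured", "known", "first", "only" and "open" are said of these compounds alone.

Measured so far:

compound 1, `ClCc1cccc(Cn2cnc3c(Cl)ncnc32)c1`, 74100 nM
compound 2, `ClCc1ccc(Cn2cnc3nc(Cl)nc(Cl)c32)cc1`, > 100000 nM
compound 3, `ClCc1cccc(Cn2cnc3c(Cl)nc(Cl)nc32)c1`, > 100000 nM

In a functional assay on COLO 205 cells (Homo sapiens) for cytotoxicity, read by sulforhodamine B assay, with a stated time of 48 h (a lower number here means that less compound is tolerated, a higher number that more compound is tolerated), compound 1 gives 74100 nM. Compound 3 reaches only a limit of the assay, > 100000 nM. Compound 2 likewise reaches only a limit, > 100000 nM. The change from compound 3 to compound 1 is hydrogen in place of chloro on an aromatic carbon, and it brought an at least 1.3-fold lower number from compound 3 to compound 1 (0.13 log units; that floor lies within the scatter).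

Compound 4, `ClCc1ccc(Cn2cnc3ncnc(Cl)c32)cc1`, is still to be measured. It arises from compound 2 by hydrogen in place of chloro on an aromatic carbon, the same change as that from compound 3 to compound 1. The difference between the core of compound 2 and the core of compound 3 is not broken down here.

For compound 4 a step of about an at least 1.2-fold lower number from compound 2 to compound 4 (0.09 log units; that floor lies within the scatter) is expected, resting on an at least 1.3-fold lower number from compound 3 to compound 1 (0.13 log units; that floor lies within the scatter). Compound 4 is therefore estimated at 80000 nM, within 40000 nM to 150000 nM.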

Compound 4, concentration lethal to 50% of the cells: 7410 nM
Compound 4: the middle estimate sits 11-fold (1.03 log units) above what was measured; the whole stated range lies above it.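

In this assay, hydrogen in place of chloro on the aromatic carbon between two ring nitrogen atoms gave an at least 13-fold lower number from compound 2 to compound 4 (1.13 log units; beyond the scatter). Set beside the earlier step, this shows that the small floor seen on one core was no safe guide to the step on the other, but it does not show that the change truly acts differently on the two cores: the same change on two cores in this assay, an at least 1.3-fold lower number (0.13 log units; that floor lies within the scatter) from compound 3 to compound 1 and an at least 13-fold lower number (1.13 log units; beyond the scatter) from compound 2 to compound 4; the limit leaves it open whether they differ Compound 2 and compound 3 each stand at a limit of the assay, so the true size of each step stays unknown: the limit of > 100000 nM in this assay, at which 2 of the 4 values shown sit.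

The compounds shown leave open what an amine or a methoxy group would give at that same carbon. They also leave open how this change would behave on any further core.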